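Phenyl for Isobutyl on the Selenocyanate Carbamate

The source may hold more compounds than are shown below. What is called first, only, known or untested is meant among the compounds shown, and "the series" means these compounds.

Compound 1 `CC(C)COC(=O)Nc1ccc([Se][Se]c2ccc(NC(=O)OCC(C)C)cc2)cc1` gives 10500 nM in an ADME assay on 184B5 cells (Homo sapiens) for cytotoxicity, read by MTT assay, with a stated time of 72 h; on this read-out higher numbers stand for weaker inhibition of growth and lower numbers for stronger inhibition of growth.
Compound 2 `CCOC(=O)Nc1ccc([Se][Se]c2ccc(NC(=O)OCC)cc2)cc1` gives 16700 nM in this assay.
Compound 3 `CC(C)COC(=O)Nc1ccc([Se]C#N)cc1` gives 21600 nM in this assay.

Among the three measured compounds, compound 3 stands at the highest number in this assay, that is, at the weakest inhibition of growth of the three. Its nearest neighbour is compound 2, whose number lies within the usual scatter of that of compound 3, so no order between these two can be read from the data. Compound 1 lies further off, with a number lower than that of compound 3 by a margin beyond the scatter.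

Compound 4 `N#C[Se]c1ccc(NC(=O)Oc2ccccc2)cc1` has not yet been measured. It differs from compound 3 by phenyl in place of isobutyl on an oxygen next to a carbonyl group. For the measured compounds named here, none of the measured pairs differs in one place only, so the data hold no single-point comparison from which the effect of such a change could be read. Without such a comparison, the step is expected to be small, a 1.2-fold lower number from compound 3 to compound 4 (0.08 log units; within the scatter), with no direction that reaches beyond the scatter. Compound 4 is accordingly expected to give about 18000 nM, within a range from 7000 nM to 45000 nM.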

Compound 4, concentration for total growth inhibition: 22700 nM
For compound 4 the middle estimate is 1.3-fold (0.10 log units) below the measured one; low and high end bracket the measured number.
By their numbers in this assay, from the lowest: compounds 1, 2, 3 and 4 (each within the scatter of the next, the first and the last beyond it).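

For the compounds shown here, compound 3 and compound 4 form the first pair here that differs in one place only, so the change on an oxygen next to a carbonyl group can now be read directly: in this assay phenyl in place of isobutyl gives a 1.1-fold higher number from compound 3 to compound 4 (0.02 log units; within the scatter) and thus no change that can be told from the scatter. In this pair, a group with one six-membered aromatic ring of carbon only therefore takes the place of a group with no ring, and the read-out of growth inhibition stays within the scatter. The data at hand offer no measurement that would account for this result.

Because only this one exchange has been shown at this position, it remains open whether a longer chain, a chain ending in an amine or a carboxylic acid, or a phenyl ring carrying a fluorine atom would also leave the number within the scatter. On these data alone, it also remains open whether phenyl in place of isobutyl would give a similarly small step on the core of compound 1, or in cells other than those of this assay.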